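The source may hold more compounds than are shown below. What is called first, only, known or untested is meant among the compounds shown, and "the series" means these compounds.

Compound 1 `CNC(=O)N1CCCc2ccc(NC(=O)c3ccc(-c4ccccc4)cc3)cc21` gives 19.7% in a functional assay on MV4-11 cells (Homo sapiens) for antiproliferative activity, with a stated time of 6 days, tested at 1.56 uM (on this read-out lower numbers stand for a weaker effect and higher numbers for a stronger effect at the one concentration tested), the second highest of the three numbers in hand. Compound 2 `CNC(=O)N1CCCc2ccc(NC(=O)c3cccc(-c4cnn(S(C)(=O)=O)c4)c3)cc21` gives 1.6%, and compound 3 `CNC(=O)N1CCCc2ccc(NC(=O)c3cccc(-c4cnn(C)c4)c3)cc21` gives 71.2%. Going by the values given here, the one measured single-point step, a number 69.6 percentage points higher from compound 2 to compound 3 (beyond the scatter), concerns methyl in place of methylsulfonyl on an aromatic nitrogen and says nothing about the change now in question.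

Compound 4 `CNC(=O)N1CCCc2ccc(NC(=O)c3ccc(-c4cccnc4)cc3)cc21` differs from compound 1 as follows: pyridin-3-yl in place of phenyl on an aromatic carbon. Among the compounds with values here, no measured pair shows this exchange, so there is no step of known size to lean on; compound 3 carries a different five-membered aromatic group on the core and cannot be read across. With no evidence of a shift, the expected step in this assay, a number 5.3 percentage points higher from compound 1 to compound 4 (within the scatter), is small and may well lie within the scatter, with a slight lean upward. Compound 4 is therefore estimated at 25%, within a range of 5% to 55%.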

Compound 4, a percentage reported as inhibition, at one concentration (the size of the read-out at that concentration, not a potency): 62.5%
Compound 4: middle estimate off by 37.5 percentage points, on the low side; the whole stated range lies below it.
By their numbers in this assay, from the lowest: compound 2; then compound 1; then compounds 4 and 3 (each within the scatter of the next).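

In this assay, pyridin-3-yl in place of phenyl on an aromatic carbon, para to a large group, gives a number 42.8 percentage points higher from compound 1 to compound 4 (beyond the scatter), the first measured sign that this position responds strongly to a change within the ring. The two groups have the same number of heavy atoms and differ by one ring nitrogen in place of a carbon and by one hydrogen-bond acceptor, so a very small edit to the ring is enough for a step of this size. Nothing measured on these compounds explains the shift.

Open, from the compounds shown here alone, is whether the place of the ring nitrogen matters, as pyridin-2-yl or pyridin-4-yl at this position would show. Also open, going by these compounds, is how an amine or a carboxylic acid on the pyridine ring would change the read-out.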